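Thiosemicarbazone aryl replacement: methoxyphenyl to pyrrolyl

The source may report more compounds than this note shows. Statements on the series, on what has been measured and on what is new or still open speak of the compounds shown alone.

Measured compounds:
compound 1 `COc1ccc(/C=N/NC(=S)NC(C)(C)[C@H]2CC=C(C)CC2)cc1`, 13300 nM
compound 2 `CC1=CC[C@H](C(C)(C)NC(=S)N/N=C/c2ccc(N(C)C)cc2)CC1`, 45100 nM
compound 3 `CC1=CC[C@H](C(C)(C)NC(=S)N/N=C/c2ccccc2[N+](=O)[O-])CC1`, 10600 nM

Three thiosemicarbazones sharing the same core were tested in a functional assay on UACC-62 cells (Homo sapiens) for inhibition, read by sulforhodamine B assay, with a stated time of 48 h; a higher number here means a weaker inhibitor of growth, a lower number a stronger inhibitor of growth. Compound 1 gives 13300 nM, and compound 3 gives 10600 nM; the two lie within the scatter of each other. Compound 2 gives 45100 nM and is the only one set apart beyond the scatter, with the higher number. Within the data shown here, the single measured step, a 3.4-fold higher number from compound 1 to compound 2 (0.53 log units; beyond the scatter), is a modest one.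

The new compound 4 `CC1=CC[C@H](C(C)(C)NC(=S)N/N=C/c2ccc[nH]2)CC1` differs from compound 1 in one place: 1H-pyrrol-2-yl in place of 4-methoxyphenyl on a carbon with a double bond to nitrogen. Among the measured compounds shown here, no measured step touches this change. For the measured compounds named here, the only step available, from compound 1 to compound 2, changed a substituent on the aromatic ring rather than the ring itself, so it offers little direct guidance; it does show that the series as a whole has stayed within a narrow band in this assay. With nothing in the data to indicate a large move, compound 4 is expected to land near compound 1, with the estimated step being a 1.1-fold higher number from compound 1 to compound 4 (0.05 log units; within the scatter). For compound 4 the estimate in this assay is 15000 nM, within a range from 5000 nM to 50000 nM.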

Compound 4, concentration for 50% growth inhibition: 14800 nM
Compound 4: the middle estimate sits 1.0-fold (0.01 log units) above what was measured; the range from low to high includes it.
By their numbers in this assay, from the lowest: compounds 3, 1 and 4 (each within the scatter of the next); then compound 2.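

In this assay, replacing the whole aryl group on a carbon with a double bond to nitrogen gives a 1.1-fold higher number from compound 1 to compound 4 (0.05 log units; within the scatter). The earlier step changed only a substituent on the aromatic ring, whereas this one replaces the ring itself: 4-methoxyphenyl, with 8 heavy atoms, a six-membered aromatic ring of carbon only and 1 hydrogen-bond acceptor, gives way to 1H-pyrrol-2-yl, with 5 heavy atoms, a five-membered aromatic ring with 1 hetero atom and 1 hydrogen-bond donor, and the step still lies within the scatter. No evidence is at hand to explain this result.

The compounds shown leave open whether the hydrogen on the pyrrole nitrogen matters, a question that 1-methyl-1H-pyrrol-2-yl at the same place would address, and whether other five-membered rings, such as furan-2-yl or thiophen-2-yl, would read the same. Among these compounds, they also leave open how a substituent on the pyrrole ring, such as a carboxylic acid, an amine or a nitro group, would shift the number, given that the single substituent step on the six-membered ring, a 3.4-fold higher number from compound 1 to compound 2 (0.53 log units; beyond the scatter), lies beyond the scatter.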